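This account rests on a few compounds, and the source may have more. Where it says the series, first, only, none or still open, it means among the compounds named here.

Compound 2 `CC(=O)Nc1cc(C)n(Cc2cc(Cl)ccc2OCc2ccccc2)n1` was measured in a physicochemical assay for lipophilicity, at pH 7.4 (a lower number here means a more polar compound, a higher number a more lipophilic compound), and gave only a limit, > 3.7, so its true position is not a number. For the measured compounds named here, its one measured neighbour, compound 1 `Cc1cc(C(=O)Nc2ccccc2)nn1Cc1cc(Cl)ccc1OCc1ccccc1`, likewise gave only a limit in this assay, > 3.7. Between them the step that the two limits leave unreadable from compound 1 to compound 2 therefore stays unreadable, since both values sit at the limit of > 3.7 in this assay, at which 2 of the 2 values shown sit. Compound 3 `Cc1cc(NC(=O)OCc2ccccn2)nn1Cc1cc(Cl)ccc1OCc1ccccc1` is not yet measured; it differs from compound 2 by (pyridin-2-yl)methoxy in place of methyl on a carbonyl carbon. Going by the values given here, no measured step covers a change of this kind, so nothing here tells its size or direction. The estimated step that the limit leaves unreadable from compound 2 to compound 3 is expected to be small and upward, because compound 2 already gives > 3.7. For compound 3 the expected value in this assay is 4.3, within 3.7 to 5, and it is most likely to be reported again only as a limit.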

Compound 3, distribution coefficient: 3.1
Estimate against measurement, compound 3: 1.20 log units above, and the stated range ends above it.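

Compound 3 is the only compound shown with an actual number in this assay: compound 3 gives 3.1. Putting (pyridin-2-yl)methoxy in place of methyl on a carbonyl carbon gives a number at least 0.60 log units lower from compound 2 to compound 3 (beyond the scatter), so this position can clearly move the read-out, and the larger exchange of phenylcarbamoyl for (((pyridin-2-yl)methoxy)carbonyl)amino on an aromatic carbon gives a number at least 0.60 log units lower from compound 1 to compound 3 (beyond the scatter). The full size of these steps stays unknown and the step between compound 1 and compound 2 cannot be read, because both of those compounds gave only a limit: the limit of > 3.7 in this assay, at which 2 of the 3 values shown sit.

The (pyridin-2-yl)methoxy group enters as one piece, so the share of its oxygen and the share of its ring cannot be told apart. As far as these compounds go, whether a plain methoxy or an amine such as dimethylamino on the same carbonyl carbon would also bring the number down remains open.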